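Swapping a Methylphenyl for a Methoxypyridinyl

This account rests on a few compounds, and the source may have more. Where it says the series, first, only, none or still open, it means among the compounds named here.

Of the compounds shown here, three have been measured in a functional assay on BJAB cells (Homo sapiens) for antiproliferative activity, with a stated time of 4 days; on this read-out higher numbers stand for an effect only at larger amounts of compound and lower numbers for an effect already at smaller amounts. Compound 1 `Cc1c(-c2cc(Cl)cc(Cl)c2)c(C(=O)O)nn1-c1nc(-c2cccnc2)c(SC(C)C)s1` is reported as "not active" (no number reported) in this assay. Compound 2 `CCSc1sc(-n2nc(C)c(Cc3ccccc3[N+](=O)[O-])c2C(=O)O)nc1-c1ccc(Cl)c(Cl)c1` gives 59000 nM in this assay. Compound 3 `Cc1ccccc1-c1c(C)nn(-c2nc(-c3ccc(Cl)c(Cl)c3)c(SC(C)C)s2)c1C(=O)O` gives 5500 nM in this assay, the lower of the two numbers, and its gap to compound 2 lies beyond the usual scatter. Compound 4 `COc1cncc(-c2c(C)nn(-c3nc(-c4ccc(Cl)c(Cl)c4)c(SC(C)C)s3)c2C(=O)O)c1` differs from compound 3 in one place: 5-methoxypyridin-3-yl in place of 2-methylphenyl on an aromatic carbon. Going by the values given here, no two measured compounds differ in just this way, so nothing here shows what such a swap does. The step expected is a 1.1-fold higher number from compound 3 to compound 4 (0.04 log units; within the scatter), small and within the scatter, with no firm direction. Compound 4 is accordingly estimated at 6000 nM in this assay, with a range from 1500 nM to 25000 nM.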

Compound 4, half-maximal effective concentration: 21000 nM
Compound 4: the middle estimate sits 3.5-fold (0.54 log units) below what was measured; measured number inside the range.
By their numbers in this assay, from the lowest: compound 3; then compound 4; then compound 2.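

In this assay, placing 5-methoxypyridin-3-yl instead of 2-methylphenyl on the aromatic carbon next to the ring atom that bears a carboxy group gives a 3.8-fold higher number from compound 3 to compound 4 (0.58 log units; beyond the scatter) and this modest step lies beyond the usual scatter. This position therefore responds to the ring it carries, and here the swap means more compound is needed for the same effect. No measurement at hand explains the shift. Whether the ring nitrogen or the methoxy group accounts for the step stays open, as does the effect of an unsubstituted phenyl or an amine at this position.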